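The source may hold more compounds than are shown below. What is called first, only, known or untested is meant among the compounds shown, and "the series" means these compounds.

Measured in a functional assay on HeLa cells (Homo sapiens) for antiproliferative activity, read by CCK-8 assay, with a stated time of 72 h; on this read-out lower numbers stand for stronger inhibition of growth and higher numbers for weaker inhibition of growth:
- Compound 1 `CCC1C(=O)N(C)c2cnc(-n3ccc4cc(C(=O)NC)ccc43)nc2N1c1ccn(C)n1`: 6330 nM
- Compound 2 `CC[C@@H]1C(=O)N(C)c2cnc(-n3ccc4cc(C(=O)NC(C)C)ccc43)nc2N1C1CCCC1`: 292 nM
- Compound 3 `CC[C@@H]1C(=O)N(C)c2cnc(-n3ccc4cc(C(=O)NC5CCCC5)ccc43)nc2N1C1CCCC1`: 247 nM

Compound 1 stands highest of the three, beyond the scatter from both compound 2 and compound 3. Compound 4 `CCC1C(=O)N(C)c2cnc(-n3ccc4cc(C(N)=O)ccc43)nc2N1c1ccn(C)n1` differs from compound 1 in one place: hydrogen in place of methyl on an amide-type nitrogen. Within the data shown here, only one measured step changes a group on such a nitrogen, a 1.2-fold lower number from compound 2 to compound 3 (0.07 log units; within the scatter), and it stays within the scatter. Among the measured compounds shown here, that step swaps isopropyl for cyclopentyl in another setting, and no measured step removes the group altogether, so it is a weak guide. No step beyond the scatter is therefore expected in this assay. The expected step is a 1.1-fold lower number from compound 1 to compound 4 (0.02 log units; within the scatter). For compound 4 the estimated value is 6000 nM, within a range of 2500 nM to 15000 nM.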

Compound 4, concentration for 50% growth inhibition: 27400 nM
For compound 4 the middle estimate is 4.6-fold (0.66 log units) below the measured one; measured number outside the range, above it.
By their numbers in this assay, from the lowest: compounds 3 and 2 (each within the scatter of the next); then compound 1; then compound 4.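

Replacing methyl with hydrogen on the amide-type nitrogen gives a 4.3-fold higher number from compound 1 to compound 4 (0.64 log units; beyond the scatter) in this assay and so moves the number towards weaker inhibition of growth. Among these compounds, the only earlier step at such a nitrogen, a 1.2-fold lower number from compound 2 to compound 3 (0.07 log units; within the scatter), stayed within the scatter, so this position is now seen to respond to a change, at least on the core of compound 1. Nothing measured here accounts for the step. The compounds shown leave open how an ethyl group or a longer chain ending in an amine would read on this nitrogen with that core.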